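Sulfonylacetic acid series: cyclopropylmethoxy added to the distal ring

The source may report more compounds than this note shows. Statements on the series, on what has been measured and on what is new or still open speak of the compounds shown alone.

The compounds share one core. Compound 1 `Cc1cccc(C)c1-c1cccc(COc2ccc(SCC(=O)O)cc2)c1` carries a (carboxymethyl)sulfanyl group, and in a functional assay on CHO cells for agonist activity at Free fatty acid receptor 1 (Homo sapiens), read by FLIPR and calcium flux (a higher number here means that more compound is needed for the effect, a lower number that less compound is needed), compound 1 gives 195 nM. Compound 2 `Cc1cccc(C)c1-c1cccc(COc2ccc(S(=O)(=O)CC(=O)O)cc2)c1` is the corresponding sulfone, and in this assay compound 2 gives 66.1 nM. For the measured compounds named here, the step of a 3.0-fold lower number from compound 1 to compound 2 (0.47 log units; beyond the scatter) is the only measured step in the set. Compound 3 `COc1cc(C)c(-c2cccc(COc3ccc4c(c3)S(=O)(=O)CC4CC(=O)O)c2)c(C)c1` has a different core with a methoxy on the distal ring; in this assay compound 3 gives > 1000 nM, which is a limit of the assay and not a number (the limit of > 1000 nM in this assay, at which 1 of the 3 values shown sits). Among the numbers shown, compound 2 stands lowest of two, with compound 1 as the nearest, higher beyond the scatter.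

Compound 4 `Cc1cc(OCC2CC2)cc(C)c1-c1cccc(COc2ccc(S(=O)(=O)CC(=O)O)cc2)c1` differs from compound 2 by cyclopropylmethoxy in place of hydrogen on an aromatic carbon. Going by the values given here, no measured step touches this place: the step of a 3.0-fold lower number from compound 1 to compound 2 (0.47 log units; beyond the scatter) alters the acid-bearing sulfur group, and compound 3 differs from compound 2 in more than one place and gives only a limit. Among the compounds with values here, the change therefore has no precedent within the set; a large shift in either direction is unsupported, and only a modest one is taken into account. Compound 4 is expected to give 40 nM (range 12 nM to 130 nM). That estimate means an expected step of a 1.7-fold lower number from compound 2 to compound 4 (0.22 log units; within the scatter).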

Compound 4, half-maximal effective concentration: 79.4 nM
Compound 4: the middle estimate sits 2.0-fold (0.30 log units) below what was measured, and the stated range covers the measured number.
By their numbers in this assay, from the lowest: compounds 2 and 4 (each within the scatter of the next); then compound 1. At a limit, above all of these: compound 3.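

The aromatic carbon meta to two methyl groups and para to a large group takes cyclopropylmethoxy with no readable shift in this assay: a 1.2-fold higher number from compound 2 to compound 4 (0.08 log units; within the scatter). For the compounds shown here, this place therefore holds a group that brings a three-membered ring and an ether oxygen while the number stays level with that of compound 2, which the earlier compounds could not show, as none of them gives a readable number with a substituent here. Nothing in the information at hand bears on a cause for this result.

From the compounds shown here alone, it remains open whether this place also holds an amine, a carboxylic acid or a longer chain such as hexyloxy at a number like that of compound 4. Compound 3 gives > 1000 nM, which is a limit of the assay and not a number, and as it differs from compound 2 in more than one place, it cannot separate the contribution of its core from that of its methoxy.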